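The compounds below may be only part of what the source reports. "The series", "measured", "known", "first", "only" and "open" are said of these compounds alone.

Measured in an ADME assay on microsomes from liver (Homo sapiens) for metabolic stability, with a stated time of 10 min; a higher number here means that more of the compound is left, a lower number that less of the compound is left:
- compound 1 `C[C@]1(C(=O)O)CC[C@H](C(=O)N2CC[C@](c3ccc(C(F)(C(F)(F)F)C(F)(F)F)cc3)(S(=O)(=O)c3ccc(F)cc3)C2)CC1`: 97%
- compound 2 `CC[C@]1(C(=O)O)CC[C@H](C(=O)N2CC[C@](c3ccc(C(F)(C(F)(F)F)C(F)(F)F)cc3)(S(=O)(=O)c3ccc(F)cc3)C2)CC1`: 100%
- compound 3 `CO[C@]1(C(=O)N2CC[C@](c3ccc(C(F)(C(F)(F)F)C(F)(F)F)cc3)(S(=O)(=O)c3ccc(F)cc3)C2)CC[C@H](C(=O)O)CC1`: 82%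

Compound 3, at 82%, stands lowest of the three, and both gaps to it lie beyond the scatter: a number 15 percentage points lower from compound 1 to compound 3 (beyond the scatter) and a number 18 percentage points lower from compound 2 to compound 3 (beyond the scatter). Compound 1 and compound 2 cannot be told apart, with a number 3 percentage points higher from compound 1 to compound 2 (within the scatter).

Compound 4 `C[C@]1(C(=O)N2CC[C@](c3ccc(C(F)(C(F)(F)F)C(F)(F)F)cc3)(S(=O)(=O)c3ccc(F)cc3)C2)CC[C@@H](C(=O)O)CC1` keeps the shared core and differs from compound 3 in one group: 4-carboxy-1-methylcyclohexyl in place of 4-carboxy-1-methoxycyclohexyl on a carbonyl carbon. In words, this is 4-carboxy-1-methylcyclohexyl in place of 4-carboxy-1-methoxycyclohexyl on a carbonyl carbon.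

Among the compounds with values here, no measured step makes exactly this exchange. The closest evidence is the pair of modest steps into compound 3, and each of these also moves the group that differs, since compound 1 carries 4-carboxy-4-methylcyclohexyl and compound 2 carries 4-carboxy-4-ethylcyclohexyl. They therefore transfer only in part. Both point the same way, so a modest rise in this assay is expected, of similar size to those steps but opposite in direction. The estimated step is a number 12 percentage points higher from compound 3 to compound 4 (beyond the scatter). For compound 4 the expected value is 94%, with an estimated range of 80% to 100%.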

Compound 4, percent of the compound remaining: 85%
The estimate for compound 4 lay 9 percentage points above the measured number; measured number inside the range.
By their numbers in this assay, from the lowest: compounds 3 and 4 (each within the scatter of the next); then compounds 1 and 2 (each within the scatter of the next).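

In this assay, the exchange on the carbonyl carbon gives a number 3 percentage points higher from compound 3 to compound 4 (within the scatter), so 4-carboxy-1-methylcyclohexyl and 4-carboxy-1-methoxycyclohexyl cannot be told apart here. The lower numbers earlier seen with compound 3 are thus not confined to the methoxy-bearing group: a number 12 percentage points lower from compound 1 to compound 4 (beyond the scatter) and a number 15 percentage points lower from compound 2 to compound 4 (beyond the scatter) show that the methyl-bearing 4-carboxy-1-methylcyclohexyl also sits apart from 4-carboxy-4-methylcyclohexyl and 4-carboxy-4-ethylcyclohexyl in this read-out. No measurement available here accounts for these steps.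

Whether this separation depends on the methyl or methoxy of the 4-carboxy-1-substituted groups, or on the arrangement of the cyclohexyl group as a whole, remains open, as the compounds shown include no 4-carboxycyclohexyl group with only hydrogen in that place. From the compounds shown here alone, how an ethyl, a fluorine or an amine on the same ring carbon of the 4-carboxy-1-substituted cyclohexyl group would read in this assay also remains open, and such compounds would show whether the two close values of compound 3 and compound 4 extend to other groups.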